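Triazole exchange on the aryl arm of the urea series

The source may hold more compounds than are shown below. What is called first, only, known or untested is meant among the compounds shown, and "the series" means these compounds.

Measured compounds:
compound 1 `Cc1cc(C)c(NC(=O)N(Cc2ccc(-c3ccccc3)s2)C2CCCCCC2)c(C)c1`: 46 nM
compound 2 `Cc1cc(C)c(NC(=O)N(Cc2ccc(-c3n[nH]c(C)n3)cc2)C2CCCCCC2)c(C)c1`: 120 nM
compound 3 `Cc1cc(C)c(NC(=O)N(Cc2cccc(-c3cnn(C)c3)c2)C2CCCCCC2)c(C)c1`: 44 nM

All three were run in an assay on microsomes from intestine for inhibition of acyl-CoA:cholesterol acyltransferase (Oryctolagus cuniculus); a lower number here means a stronger inhibitor, a higher number a weaker inhibitor. Compound 2 stands with the highest number of the three, and its gap to compound 1 and to compound 3 lies beyond the usual scatter of this assay in both cases. Compound 1 and compound 3 sit within the scatter of each other, so no order between those two can be read.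

Compound 4 `Cc1cc(C)c(NC(=O)N(Cc2ccc(-n3ccnn3)cc2)C2CCCCCC2)c(C)c1` has not been measured in this assay. It differs from compound 2 in one place: 1H-1,2,3-triazol-1-yl in place of 5-methyl-1H-1,2,4-triazol-3-yl on an aromatic carbon. The ring that leaves and the ring that enters are both five-membered aromatic rings with three hetero atoms; the incoming ring has one heavy atom fewer, no hydrogen-bond donor and one more hydrogen-bond acceptor.

Among the measured compounds shown here, no step between two measured compounds isolates this kind of exchange, so the expectation rests on the spread of the three numbers. For the step from compound 2 to compound 4 in this assay, a small move toward a lower number is expected, about at the edge of the scatter, written as a 1.4-fold lower number from compound 2 to compound 4 (0.15 log units; within the scatter). Compound 4 is accordingly expected near 85 nM, with a range from 30 nM to 250 nM.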

Compound 4, half-maximal inhibitory concentration: 42 nM
Compound 4: middle estimate off by 2.0-fold (0.31 log units), on the high side, within the range that was stated.
By their numbers in this assay, from the lowest: compounds 4, 3 and 1 (each within the scatter of the next); then compound 2.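

In this assay, among the compounds shown here, 1H-1,2,3-triazol-1-yl in place of 5-methyl-1H-1,2,4-triazol-3-yl, on an aromatic carbon para to a large group, gives a 2.9-fold lower number from compound 2 to compound 4 (0.46 log units; beyond the scatter), the first step in this set that isolates a change in one place. The higher number of compound 2 is therefore not shared by every five-membered aromatic ring with 3 hetero atoms at this position, and the ring with 0 hydrogen-bond donors and 3 hydrogen-bond acceptors is accepted here with a lower number than the ring with 1 hydrogen-bond donor and 2 hydrogen-bond acceptors. The exchange changes the ring's attachment, the methyl and the hydrogen-bond count together, so this single step cannot assign the shift to any one of them, and nothing shown bears on the cause.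

The unmethylated 1H-1,2,4-triazol-3-yl group would separate the contribution of the methyl from that of the ring itself. A carboxylic acid or a primary amine at the same position would show how far this position accepts groups outside the triazole family, and the compounds shown give no reading on either.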